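This account rests on a few compounds, and the source may have more. Where it says the series, first, only, none or still open, it means among the compounds named here.

Compound 1, `CCC1(CCCCN2CCN(c3ccc(Cl)c(Cl)c3)CC2)C(=O)Nc2ccccc21`: > 20 mg/kg
Compound 2, `CCC1(CCCN2CCN(c3cccc(Cl)c3)CC2)C(=O)Nc2ccccc21`: > 20 mg/kg

Of the compounds shown here, two built on a shared core have so far been tested in a functional assay on the whole organism (strain Wistar) with Rattus norvegicus as the target, with a stated time of 5 min; a lower number here means that less compound is needed, a higher number that more compound is needed for the effect. Compound 1 does not give a number of its own in this assay but only reaches its limit, > 20 mg/kg. Compound 2 likewise stops at the limit, > 20 mg/kg. Where compound 1 stands is therefore fixed only by the limit of > 20 mg/kg in this assay, at which 2 of the 2 values shown sit, and no step between the two measured compounds can be stated in size or direction.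

Compound 3, `CCC1(CCCCN2CCN(c3cccc(OC)c3)CC2)C(=O)Nc2ccccc21`, has not yet been measured. It differs from compound 1 in a single place: 3-methoxyphenyl in place of 3,4-dichlorophenyl on an amine nitrogen in a ring. Nothing in the two measured values shows how this assay responds to a change of that kind, so the expected step is none beyond the usual scatter; the step that the estimate below means is a step that the limit leaves unreadable from compound 1 to compound 3. On that basis compound 3 is estimated at 30 mg/kg, with a range from 10 mg/kg to 100 mg/kg, and it is expected that the assay will most likely again report only its limit for compound 3.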

Compound 3, minimum effective dose: > 20 mg/kg
Compound 3 was reported as a limit; the forecaster's own chance of this, stated with the estimate: 70%; the middle value lies beyond the limit too.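

With compound 3 the read-out again gives only a limit, so no step between compound 1 and compound 3 can be read in size or direction: the limit of > 20 mg/kg in this assay, at which 3 of the 3 values shown sit.

The compounds shown leave open what dose gives the effect in this assay, and whether 3-methoxyphenyl in place of 3,4-dichlorophenyl changes that dose at all.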